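A few compounds are considered here, and "the series" means these few. Any claim that something is new, unique, unknown or untested is made for them only; others in the source may bear on it.

Measured so far:
compound 1, `COc1cc(N/C=C\C(=O)c2cn(-c3ccccc3)nc2-c2ccccc2)cc(OC)c1OC`, 6340 nM
compound 2, `COc1cc(-c2nn(-c3ccccc3)cc2C(=O)/C=C\Nc2ccc(O)cc2)cc(OC)c1OC`, 3160 nM

In a functional assay on A549 cells (Homo sapiens) for antiproliferative activity, read by MTT assay, with a stated time of 48 h (a higher number here means a weaker inhibitor, a lower number a stronger inhibitor), compound 1 gives 6340 nM and compound 2 gives 3160 nM. Compound 2 has the lowest of the two numbers, but its nearest neighbour, compound 1, sits within the scatter of it, so no order between the two can be read from the values. For the measured compounds named here, no step between measured compounds that differ in one place is available in this set.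

Compound 3, `COc1cc(N/C=C\C(=O)c2cn(-c3ccccc3)nc2-c2cc(OC)c(OC)c(OC)c2)cc(OC)c1OC`, is not yet measured in this assay. It differs from compound 2 in one place: 3,4,5-trimethoxyphenyl in place of 4-hydroxyphenyl on an amine nitrogen. The same 3,4,5-trimethoxyphenyl group already appears on that amine nitrogen in compound 1, whose value lies within the scatter of compound 2, so the two measured values give no sign that the change will move the number beyond the scatter in either direction. The step from compound 2 to compound 3 in this assay is therefore expected to be small, a 1.3-fold higher number from compound 2 to compound 3 (0.10 log units; within the scatter). Compound 3 is estimated at 4000 nM in this assay, with a range from 1300 nM to 12000 nM.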

Compound 3, half-maximal inhibitory concentration: 7980 nM
Compound 3: the middle estimate sits 2.0-fold (0.30 log units) below what was measured; the range from low to high includes it.
By their numbers in this assay, from the lowest: compounds 2, 1 and 3 (each within the scatter of the next, the first and the last beyond it).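

For the compounds shown here, at the amine nitrogen, with 3,4,5-trimethoxyphenyl held on the aromatic carbon, 3,4,5-trimethoxyphenyl in place of 4-hydroxyphenyl gives in this assay a 2.5-fold higher number from compound 2 to compound 3 (0.40 log units; beyond the scatter) as the first step that can be read beyond the scatter, though only a modest one. At the aromatic carbon, with 3,4,5-trimethoxyphenyl held on the amine nitrogen, 3,4,5-trimethoxyphenyl in place of phenyl gives a 1.3-fold higher number from compound 1 to compound 3 (0.10 log units; within the scatter) and so shows no readable movement, which leaves the amine nitrogen as the only one of these two places with a step beyond the scatter. Nothing available explains the step at the amine nitrogen.

The compounds shown leave open whether that step follows from the loss of 4-hydroxyphenyl or from the arrival of 3,4,5-trimethoxyphenyl, a question that unsubstituted phenyl or 4-aminophenyl on the amine nitrogen would help to separate. Also open, as far as these compounds go, is whether the flat result at the aromatic carbon holds for groups of another kind there, such as a carboxylic acid or a longer chain.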